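The source may report more compounds than this note shows. Statements on the series, on what has been measured and on what is new or still open speak of the compounds shown alone.

Compound 1 `COc1ccc(/C(=N/OC(C)=O)c2cccc3ccccc23)c(OC)c1OC`: 17000 nM
Compound 2 `COc1ccc(C(O)(C/C=C\c2ccccc2)c2cccc3ccccc23)c(OC)c1OC`: 12800 nM
Compound 3 `COc1ccc(C(c2ccc(OCC(=O)O)cc2)c2cccc3ccccc23)c(OC)c1OC`: > 20000 nM (a limit, not a number)

In a functional assay on MDA-MB-231 cells (Homo sapiens) for inhibition, read by sulforhodamine B assay, with a stated time of 48 h (a higher number here means a weaker inhibitor, a lower number a stronger inhibitor), compound 1 gives 17000 nM, the higher of the two numbers that were actually read. Compound 2 gives 12800 nM, which sits within the usual scatter of that reading, so the two cannot be told apart. Compound 3 returns only a limit, > 20000 nM, meaning the assay reported no number for it (the limit of > 20000 nM in this assay, at which 1 of the 3 values shown sits).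

Compound 4 `COc1ccc(/C(=N/OCC(=O)O)c2cccc3ccccc23)c(OC)c1OC` has not been measured in this assay. It differs from compound 1 in one place: carboxymethyl in place of acetyl on an oxygen. Going by the values given here, no measured pair in this set differs in just one place, so there is no directly comparable step to lean on. Compound 3 also carries a carboxymethoxy group and reaches only the limit. The step from compound 1 to compound 4 is therefore expected to run toward a higher number, roughly a 1.5-fold higher number from compound 1 to compound 4 (0.17 log units; within the scatter). Compound 4 is expected to give about 25000 nM, with a likely range from 12000 nM to 60000 nM, and a fair chance that only a limit is reported.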

Compound 4, half-maximal inhibitory concentration: > 20000 nM
Compound 4 was reported as a limit; the forecaster's own chance of this, stated with the estimate: 55%; the middle value does not contradict the limit.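

In this assay, going by these compounds alone, putting carboxymethyl in place of acetyl on an oxygen whose other neighbour is a double-bonded nitrogen gives the first step in this set that can be read: an at least 1.1-fold higher number from compound 1 to compound 4 (0.07 log units; that floor lies within the scatter). Going by these compounds, compound 4 returns a limit and not a number, so the full size of this step stays unknown, and its floor alone does not clear the usual scatter. What the step does show is that a carboxymethyl group at this position, with a hydrogen-bond donor that acetyl lacks, brings no gain in this assay: the limit of > 20000 nM in this assay, at which 2 of the 4 values shown sit.

On these data alone, whether a plain methyl or an aminoethyl group on this same oxygen would give a readable number stays open. So does whether the methyl ester of the carboxymethyl group would read like compound 1 or like compound 4.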